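The source may hold more compounds than are shown below. What is called first, only, known or untested is meant among the compounds shown, and "the series" means these compounds.

Working notes on the series in an assay on HEK293 cells for displacement of a labelled ligand from prostaglandin D2 receptor 2 (Homo sapiens); on this read-out lower numbers stand for stronger inhibition and higher numbers for weaker inhibition.

Compound 1 `Cc1c(CC(=O)O)c2ccsc2n1S(=O)(=O)c1ccc(F)cc1` gives 1630 nM in this assay. Compound 2 `Cc1c(CC(=O)O)c2ccsc2n1S(=O)(=O)c1ccc(C(F)(F)F)cc1` gives 1130 nM in this assay. Among the compounds with values here, the one step within the measured pair, a 1.4-fold lower number from compound 1 to compound 2 (0.16 log units; within the scatter), leaves compound 2 with the lowest of the two numbers, though its gap to compound 1 does not exceed the scatter, so no order between the two can be claimed.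

Compound 3 `Cc1c(CC(=O)O)c2ccsc2n1S(=O)(=O)c1ccc(S(=O)(=O)N2CCCC2)cc1` is not yet measured. Relative to compound 2 the change is (pyrrolidin-1-yl)sulfonyl in place of trifluoromethyl on an aromatic carbon. Within the data shown here, the only measured step, a 1.4-fold lower number from compound 1 to compound 2 (0.16 log units; within the scatter), concerns the same carbon of the six-membered ring but exchanges two groups far smaller than the one entering here; it says only that this position has tolerated a change without a shift beyond the scatter. Among the measured compounds shown here, no measured step bears on a sulfonyl-linked ring at this site, so nothing in the data points in either direction.

Going by these compounds, for compound 3 the expected step in this assay is therefore a 1.0-fold lower number from compound 2 to compound 3 (0.01 log units; within the scatter), that is, no change beyond the scatter, with a wide range because the change is untested. Compound 3 is estimated at 1100 nM, between 300 nM and 4000 nM.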

Compound 3, half-maximal inhibitory concentration: 390 nM
For compound 3 the middle estimate is 2.8-fold (0.45 log units) above the measured one; the measured number falls inside the stated range.
By their numbers in this assay, from the lowest: compound 3; then compounds 2 and 1 (each within the scatter of the next).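

In this assay this carbon of the six-membered aromatic ring now shows a step beyond the scatter, where the earlier pair showed none: a 2.9-fold lower number from compound 2 to compound 3 (0.46 log units; beyond the scatter) when (pyrrolidin-1-yl)sulfonyl replaces trifluoromethyl, and a 4.2-fold lower number from compound 1 to compound 3 (0.62 log units; beyond the scatter) when the same group replaces fluoro. The position therefore accepts a much larger group carrying a five-membered non-aromatic ring, and this group gives a lower number than either of the two smaller substituents, although both steps remain modest. No supporting data are available to say which feature of the entering group goes with this shift.

The compounds shown leave open whether the step belongs to the sulfonyl link or to the pyrrolidine ring; dimethylamino, piperidine or morpholine on the same sulfonyl, or a pyrrolidine joined through a carbonyl, would begin to separate the two. Also open, going by these compounds, is whether a carboxylic acid or a longer chain at this carbon would give a step of similar size, and whether the shift persists when the shared core is changed elsewhere.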